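The compounds below may be only part of what the source reports. "The series", "measured", "known", "first", "only" and "open" are said of these compounds alone.

Measured in a functional assay on HL-60 cells (Homo sapiens) for antiproliferative activity, read by resazurin assay, with a stated time of 24 h; a higher number here means a weaker inhibitor, a lower number a stronger inhibitor:
- compound 1 `CCCCCCCCc1ccc(/C=C/[C@@H](O)[C@H](CO)NC(C)=O)cc1`: 11000 nM
- compound 2 `CCCCCCCCc1ccc(/C=C/C(=O)[C@H](CO)NC(C)=O)cc1`: no result reported
- compound 3 `CC(=O)N[C@@H](CO)C(=O)/C=C/c1ccccc1`: 48000 nM

Compound 3, at 48000 nM, holds the higher of the two numbers, so it is the weaker of the pair, while compound 1 reads 11000 nM. Compound 4 `CC(=O)N[C@@H](CO)C(=O)/C=C/c1ccc(-c2ccccc2)cc1` follows from compound 3 by phenyl in place of hydrogen on an aromatic carbon, with phenyl in place of hydrogen on an aromatic carbon. For the measured compounds named here, no single-change step has been measured in this assay, so the expectation rests on thin ground. Compound 1, which carries an octyl chain but also differs elsewhere, reads 11000 nM, and this suggests a moderate gain. The estimated change is a 2.4-fold lower number from compound 3 to compound 4 (0.38 log units; beyond the scatter), a lower number, only just beyond the scatter. For compound 4 the estimate is 20000 nM, with an expected range of 7000 nM to 50000 nM.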

Compound 4, half-maximal inhibitory concentration: 50000 nM
Compound 4: the middle estimate sits 2.5-fold (0.40 log units) below what was measured; measured number inside the range.
By their numbers in this assay, from the lowest: compound 1; then compounds 3 and 4 (each within the scatter of the next).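

In this assay the series now has its first single-change step: phenyl in place of hydrogen on an aromatic carbon, para to a large group, gives a 1.0-fold higher number from compound 3 to compound 4 (0.02 log units; within the scatter) and so leaves the number unmoved. On the core of compound 3, adding this six-membered aromatic ring at this position therefore brings no gain in antiproliferative activity. No measured evidence accounts for this flat step. Open, going by these compounds, is whether a different group at this position, such as a butyl chain, an amine or a carboxylic acid, would shift the number on this core.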